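Three sulfonamides at the assay limit, a fourth awaited

The compounds below may be only part of what the source reports. "The series", "measured", "known", "first", "only" and "open" are said of these compounds alone.

Compound 1, `O=S(=O)(NC1=NCCN1C(=S)SN1CCn2c1nsc2=S)c1ccccc1`: >= 20000 nM
Compound 2, `COc1ccc(S(=O)(=O)NC2=NCCN2C(=S)SN2CCn3c2nsc3=S)cc1`: >= 20000 nM
Compound 3, `O=S(=O)(NC1=NCCN1C(=S)SN1CCn2c1nsc2=S)c1cccc(Cl)c1`: >= 20000 nM

In a functional assay on KYSE-510 cells (Homo sapiens) for antiproliferative activity, read by crystal violet staining, with a stated time of 96 h (on this read-out lower numbers stand for stronger inhibition of growth and higher numbers for weaker inhibition of growth), compound 1 gives a limit, not a number. Compound 2 likewise gives a limit in this assay. Compound 3 stands at a limit too, >= 20000 nM in this assay, so its position among the three cannot be told; all three values sit on (the limit of >= 20000 nM in this assay, at which 3 of the 3 values shown sit). The steps a step that the two limits leave unreadable from compound 1 to compound 2, a step that the two limits leave unreadable from compound 1 to compound 3 and a step that the two limits leave unreadable from compound 2 to compound 3 are therefore unreadable. Compound 4, `O=S(=O)(NC1=NCCN1C(=S)SN1CCn2c1nsc2=S)c1ccc(Cl)c(Cl)c1`, differs from compound 3 by chloro in place of hydrogen on an aromatic carbon. Among the compounds with values here, the only related measured step, chloro in place of hydrogen from compound 1 to compound 3, gives no readable size, so no change beyond the scatter in this assay can be foreseen. Compound 4 is expected to give 20000 nM (range 7000 nM to 60000 nM), a step of a number no higher from compound 3 to compound 4 (the limit leaves the size open) that is most likely another limit.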

Compound 4, concentration for 50% growth inhibition: >= 20000 nM
Compound 4 gave a limit, no number; the forecaster's own chance of this, stated with the estimate: 80%; the middle value sits exactly at the limit.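

Compound 4 stands at a limit, as do compound 1, compound 2 and compound 3, so no step to compound 4 can be read: the limit of >= 20000 nM in this assay, at which 4 of the 4 values shown sit.

The compounds shown leave open how the groups on the sulfonyl sulfur rank in this assay.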